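This account rests on a few compounds, and the source may have more. Where it says the series, first, only, none or still open, it means among the compounds named here.

Measured compounds in a functional assay on PC-3 cells (Homo sapiens) for antiproliferative activity, read by sulforhodamine B assay, with a stated time of 48 h, tested at 50 uM; on this read-out higher numbers stand for more inhibition at the one concentration tested (going by the name of the read-out) and lower numbers for less inhibition:

compound 1 `CC1=CC[C@H](C(C)C)c2cc(C)c(OC(=O)c3ccc([N+](=O)[O-])cc3)cc21` gives 36.7%
compound 2 `CC1=CC[C@H](C(C)C)c2cc(C)c(OC(=O)c3ccccc3)cc21` gives 22.5%
compound 3 `CC1=CC[C@H](C(C)C)c2cc(C)c(OC(=O)c3ccc(Cl)cc3)cc21` gives 34.1%

Compound 3 stands second highest of the three numbers. Its nearest neighbour is compound 1, and the gap is small: a number 2.6 percentage points lower from compound 1 to compound 3 (within the scatter). Its furthest neighbour is compound 2, from which it differs by a number 11.6 percentage points higher from compound 2 to compound 3 (beyond the scatter). The step of a number 14.2 percentage points lower from compound 1 to compound 2 (beyond the scatter) shows the same thing from the other side: the unsubstituted phenyl ester sits below both substituted ones.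

Compound 4 `CC1=CC[C@H](C(C)C)c2cc(C)c(OC(=O)c3cccc([N+](=O)[O-])c3)cc21` is the next member. The change from compound 3 is 3-nitrophenyl in place of 4-chlorophenyl on a carbonyl carbon. The step that bears most directly on it is a number 2.6 percentage points lower from compound 1 to compound 3 (within the scatter), which shows that swapping chloro for nitro at one position barely moved this assay. Going by the values given here, the shift of the nitro group to a different position on the ring has no measured counterpart here, so only the substituent exchange can be drawn on. Compound 4 is therefore expected to land close to compound 3, with a step of a number 1.9 percentage points higher from compound 3 to compound 4 (within the scatter) that is not expected to exceed the scatter. The estimate for compound 4 is 36%, ranging from 26% to 46%.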

Compound 4, a percentage reported as inhibition, at one concentration (the size of the read-out at that concentration, not a potency): 36.9%
Compound 4: middle estimate off by 0.9 percentage points, on the low side; measured number inside the range.
By their numbers in this assay, from the lowest: compound 2; then compounds 3, 1 and 4 (each within the scatter of the next).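

Shifting the nitro group, with 3-nitrophenyl in place of 4-nitrophenyl on the carbonyl carbon, gives a number 0.2 percentage points higher from compound 1 to compound 4 (within the scatter) in this assay, while nitro in place of hydrogen gives a number 14.4 percentage points higher from compound 2 to compound 4 (beyond the scatter), so in these two compounds the gain over the unsubstituted phenyl ester does not depend on which of the two printed ring placements the nitro group takes. The exchange of 4-chlorophenyl for 3-nitrophenyl gives a number 2.8 percentage points higher from compound 3 to compound 4 (within the scatter), so these two substituted rings cannot be told apart on this read-out. No measurement here explains why the substituted esters stand above the unsubstituted one.

The compounds shown leave open whether an amine, a carboxylic acid or a methoxy group on this ring would behave like nitro and chloro. Also open, on these data alone, is whether an amide in place of the ester would hold these numbers, and how the compounds compare in potency, as the read-out covers a single concentration.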